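The source may report more compounds than this note shows. Statements on the series, on what has been measured and on what is new or still open speak of the compounds shown alone.

The measured compounds in this set are:

Compound 1, `COc1cc2ncnc(Nc3cccc(Cl)c3)c2cc1OCCCCC(=O)Nc1ccc(S(N)(=O)=O)cc1`: in a functional assay on A-431 cells (Homo sapiens) for antiproliferative activity, read by MTT assay, with a stated time of 72 h (on this read-out higher numbers stand for weaker inhibition and lower numbers for stronger inhibition), compound 1 gives 30400 nM.
Compound 2, `COc1ccc(Nc2ncnc3cc(OC)c(OCCCCC(=O)Nc4ccc(S(N)(=O)=O)cc4)cc23)cc1OC`: in this assay compound 2 gives 35400 nM.
Compound 3, `C#Cc1cccc(Nc2ncnc3ccc(NC(=S)Nc4ccc(S(N)(=O)=O)cc4)cc23)c1`: in this assay compound 3 gives 15300 nM.

Compound 3 gives the lowest of the three numbers. Its gap to compound 1 lies within the scatter of repeated measurements, so the two cannot be ordered; only compound 2 stands beyond the scatter above it.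

Compound 4, `NS(=O)(=O)c1ccc(NC(=S)Nc2ccc3ncnc(Nc4cccc(F)c4)c3c2)cc1`, differs from compound 3 in one place: fluoro in place of ethynyl on an aromatic carbon. For the measured compounds named here, the only measured single-point step, a 1.2-fold higher number from compound 1 to compound 2 (0.07 log units; within the scatter), concerns a change of the aryl group on the nitrogen of the shared core, and it did not move the number beyond the scatter. Going by the values given here, it bears on the present change only loosely, and no measured step touches the same position as the change from compound 3 to compound 4. Nothing in the data therefore points to a step of any particular direction, and compound 4 is expected to lie close to compound 3, with a 1.0-fold lower number from compound 3 to compound 4 (0.01 log units; within the scatter) as the expected step. On that basis compound 4 is estimated at 15000 nM in this assay, within a range from 6000 nM to 38000 nM.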

Compound 4, half-maximal inhibitory concentration: 30100 nM
Estimate against measurement, compound 4: 2.0-fold (0.30 log units) below; the measured number falls inside the stated range.
By their numbers in this assay, from the lowest: compounds 3, 4, 1 and 2 (each within the scatter of the next, the first and the last beyond it).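

In this assay the exchange of ethynyl, with its two carbons and its triple bond, for fluoro on this aromatic carbon gives a 2.0-fold higher number from compound 3 to compound 4 (0.29 log units; within the scatter) and so leaves compound 3 and compound 4 without an order. For the compounds shown here, this is the only measured step at this carbon, and it shows that a single fluorine can take the place of the ethynyl group here without a difference beyond the scatter, which the earlier step, a 1.2-fold higher number from compound 1 to compound 2 (0.07 log units; within the scatter) on exchanging the whole aryl group on the nitrogen, could not show for this substituent. The data shown offer no measured finding that would explain the size of this step.

On these data alone, whether a bromo group, a nitrile or an amine on the same aromatic carbon would also stay within the scatter of compound 3 remains open. Also open, as far as these compounds go, is whether the exchange of ethynyl for fluoro would give a similar step on the core of compound 1, with its longer chain carrying the amide, or whether a carboxylic acid in place of the sulfonamide would change the picture.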